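Cyclohexyl in place of allyl: a lipophilicity estimate

The source may hold more compounds than are shown below. What is called first, only, known or untested is meant among the compounds shown, and "the series" means these compounds.

The three measured compounds share one core and differ only in the group on the aromatic-ring nitrogen. Compound 1 `C=CCN(C1=NCCN1)c1c(Br)cccc1Br` gives in a physicochemical assay for lipophilicity (on this read-out lower numbers stand for lower lipophilicity and higher numbers for higher lipophilicity), a value of -0.75, the lowest of the three. Compound 2 `Brc1cccc(Br)c1N(CC1CCCC1)C1=NCCN1` gives 0.32 and compound 3 `Brc1cccc(Br)c1N(Cc1ccccc1)C1=NCCN1` gives -0.05. The step of a number 1.07 log units higher from compound 1 to compound 2 (beyond the scatter) is the larger of the two steps out of compound 1; the step of a number 0.70 log units higher from compound 1 to compound 3 (beyond the scatter) is smaller, and between them lies a number 0.37 log units lower from compound 2 to compound 3 (beyond the scatter).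

Compound 4 `Brc1cccc(Br)c1N(C1=NCCN1)C1CCCCC1` is not yet measured. It differs from compound 1 by cyclohexyl in place of allyl on a nitrogen on an aromatic ring. The closest guide is the step to compound 2, since cyclopentylmethyl and cyclohexyl carry the same count of six carbons, and the step to compound 3 points in the same direction. The account therefore expects compound 4 to rise beyond the scatter, by about a number 1.05 log units higher from compound 1 to compound 4 (beyond the scatter) in this assay. Compound 4 is estimated at 0.3, with a range from -0.2 to 0.8.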

Compound 4, distribution coefficient: 0.14
For compound 4 the middle estimate is 0.16 log units above the measured one; low and high end bracket the measured number.
By their numbers in this assay, from the lowest: compound 1; then compounds 3, 4 and 2 (each within the scatter of the next, the first and the last beyond it).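

With cyclohexyl on the nitrogen on an aromatic ring, this assay gives a number 0.89 log units higher from compound 1 to compound 4 (beyond the scatter), so a ring of carbon only, set directly on that nitrogen, also stands clearly apart from allyl. Cyclohexyl cannot be told from the two other groups, since a number 0.19 log units higher from compound 3 to compound 4 (within the scatter) and a number 0.18 log units lower from compound 2 to compound 4 (within the scatter) are both within the scatter, although a number 0.37 log units lower from compound 2 to compound 3 (beyond the scatter) keeps benzyl and cyclopentylmethyl apart from each other. No measurement shown here accounts for these steps.

The compounds shown leave open how a longer open chain, such as hexyl, would stand at this place on this read-out. They also leave open what an amine or a carboxylic acid carried on the cyclohexyl ring would do to the step from allyl.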